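The compounds below may be only part of what the source reports. "The series", "measured", "known", "first", "only" and "open" are said of these compounds alone.

Compound 1 `CN1CCN(CCCCCn2c3c(c4ccccc42)C(=O)c2c[n+]([O-])c4ccccc4c2C3=O)CC1`: 1640 nM
Compound 2 `O=C1c2c[n+]([O-])c3ccccc3c2C(=O)c2c1c1ccccc1n2Cc1cn(C[C@@H](O)CO)nn1`: 490 nM
Compound 3 `O=C1c2c[n+]([O-])c3ccccc3c2C(=O)c2c1c1ccccc1n2CCCCN1CCNCC1`: 1380 nM

These three were measured in a toxicity assay on L02 cells (Homo sapiens) for cytotoxicity, read by MTT assay, with a stated time of 72 h; a lower number here means a stronger inhibitor, a higher number a weaker inhibitor. Compound 2 gives the lowest number of the three: the steps of a 3.3-fold lower number from compound 1 to compound 2 (0.52 log units; beyond the scatter) and a 2.8-fold higher number from compound 2 to compound 3 (0.45 log units; beyond the scatter) both lie beyond the scatter, while a 1.2-fold lower number from compound 1 to compound 3 (0.07 log units; within the scatter) does not. Compound 4 `CC1(C)OC[C@@H](Cn2cc(Cn3c4c(c5ccccc53)C(=O)c3c[n+]([O-])c5ccccc5c3C4=O)nn2)O1` differs from compound 2 in one place: 2,2-dimethyl-1,3-dioxolan-4-yl in place of 1,2-dihydroxyethyl on a saturated chain carbon bound to an aromatic nitrogen. For the measured compounds named here, no measured step tests this change; the two steps involving compound 2 each exchange the whole group on the saturated chain carbon bound to an aromatic nitrogen and were modest. The change to compound 4 keeps the 1,2,3-triazol-4-yl, so no step beyond the scatter is expected in this assay. Compound 4 is expected to give 600 nM, between 250 nM and 1500 nM, an expected 1.2-fold higher number from compound 2 to compound 4 (0.09 log units; within the scatter).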

Compound 4, half-maximal inhibitory concentration: 2900 nM
Beside the measured number, compound 4's estimate is 4.8-fold (0.68 log units) below it, and the stated range ends below it.
By their numbers in this assay, from the lowest: compound 2; then compounds 3, 1 and 4 (each within the scatter of the next, the first and the last beyond it).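

Putting 2,2-dimethyl-1,3-dioxolan-4-yl in place of 1,2-dihydroxyethyl, with the 1,2,3-triazol-4-yl kept, produces a 5.9-fold higher number from compound 2 to compound 4 (0.77 log units; beyond the scatter) in this assay. For the compounds shown here, this position therefore responds to a change confined to the outer end of the group, which the earlier steps could not show, as each exchanged the whole group on the saturated chain carbon. Nothing measured here gives a reason for this step.

The compounds shown leave open whether the loss of both hydrogen-bond donors or the added ring matters more. A single methyl ether of the 1,2-dihydroxyethyl, or an amine or a carboxylic acid in its place, would help separate these.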